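Paw edema series: removing one methoxy from compound 2

The compounds below may be only part of what the source reports. "The series", "measured", "known", "first", "only" and "open" are said of these compounds alone.

Of the compounds shown here, two have been measured in a functional assay on the whole organism (strain albino) for inhibition, with Rattus norvegicus as the target, read by paw edema, with a stated time of 5 h, at a dose of 0.28 mmol/kg by the oral route; on this read-out higher numbers stand for more inhibition at the one dose given (going by the name of the read-out) and lower numbers for less inhibition. Compound 1 `COc1ccc(-c2nnc(SC/C(=N/O)c3ccccc3)n2-c2ccccc2)cc1` gives 73% in this assay. Compound 2 `CCn1c(SC/C(=N/O)c2ccccc2)nnc1-c1ccc(OC)c(OC)c1` gives 71% in this assay. Among the measured compounds shown here, compound 2 stands within the usual scatter of compound 1, the only other number, so the two cannot be told apart on the read-out. For the measured compounds named here, no pair differing in a single place has been measured, and the two compounds differ from each other in more than one place, so no isolated step is available from the data.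

Compound 3 `CCn1c(SC/C(=N/O)c2ccccc2)nnc1-c1ccc(OC)cc1` is the next compound to be measured in this assay. Compound 3 differs from compound 2 by hydrogen in place of methoxy on an aromatic carbon. Both measured compounds carry a methoxy group on the same six-membered aromatic ring, so a methoxy at that ring is kept in compound 3.

Going by the values given here, with no step between measured compounds to go on, and two measured numbers lying within the scatter of each other, the expected step of a number 2 percentage points lower from compound 2 to compound 3 (within the scatter) is none beyond the scatter. Compound 3 is expected to give 69% in this assay, with a range from 56% to 80%.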

Compound 3, a percentage reported as inhibition, in the whole organism at one dose (the size of the read-out at that dose, not a potency): 71%
Beside the measured number, compound 3's estimate is 2 percentage points below it; the range from low to high includes it.
By their numbers in this assay, from the lowest: compounds 2, 3 and 1 (each within the scatter of the next).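

In this assay, among the compounds shown here, hydrogen in place of methoxy on an aromatic carbon, ortho to a methoxy group, gives no change at the digits printed from compound 2 to compound 3 (within the scatter); this is the first isolated step at this position, and it shows that the read-out at this one dose does not depend on keeping both methoxy groups on the ring. The second isolated step, ethyl in place of phenyl on an aromatic nitrogen, gives a number 2 percentage points lower from compound 1 to compound 3 (within the scatter), so the read-out does not separate these two groups on that nitrogen when the ring carries a single methoxy. Nothing available explains why either change leaves the read-out within the scatter.

Going by these compounds, all three compounds keep a methoxy on this ring, so it remains open whether the read-out would hold with hydrogen at that remaining place, or with a hydroxyl, a chlorine or a dimethylamino group there. On these data alone, the nitrogen position is also open beyond ethyl and phenyl, for example to a propyl or benzyl group, and a single dose cannot show whether compounds that read alike also match in potency.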